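Swapping the benzamide ring in a weakly antiproliferative series

A few compounds are considered here, and "the series" means these few. Any claim that something is new, unique, unknown or untested is made for them only; others in the source may bear on it.

Measured compounds:
compound 1, `O=C(Nc1ccc(Cl)c(-c2nnc3c(Cl)cccn23)c1)c1ccc(C(F)(F)F)cc1F`, 62800 nM
compound 2, `CS(=O)(=O)c1ccc(C(=O)Nc2ccc(Cl)c(-c3nnc4c(Cl)cccn34)c2)c(Cl)c1`, > 100000 nM
compound 3, `O=C(Nc1ccc(Cl)c(-c2nnc3c(Cl)cccn23)c1)c1ccc(Cl)cc1`, 58400 nM

Three amides sharing one core have been tested in a functional assay on MCF7 cells (Homo sapiens) for antiproliferative activity, read by MTT assay, with a stated time of 72 h; on this read-out lower numbers stand for stronger inhibition and higher numbers for weaker inhibition. Compound 3 carries a 4-chlorophenyl on the carbonyl carbon and gives 58400 nM. Compound 1 gives 62800 nM, a number within the scatter of compound 3, so the two cannot be told apart. Among the measured compounds shown here, for compound 2 the result is only a limit of the assay, > 100000 nM, not a number; it is the one value sitting at the limit of > 100000 nM in this assay, at which 1 of the 3 values shown sits. Among the two numbers shown, compound 3 has the lower one, but no step between measured compounds is available, so nothing ties a particular ring to a particular number.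

Compound 4, `O=C(Nc1ccc(Cl)c(-c2nnc3c(Cl)cccn23)c1)c1ccc(F)cc1Cl`, is not yet measured. It differs from compound 3 by 2-chloro-4-fluorophenyl in place of 4-chlorophenyl on a carbonyl carbon. For the measured compounds named here, both rings that have given numbers so far sit close together, and the change from compound 3 to compound 4 keeps a halogen-bearing six-membered ring on the carbonyl carbon, so the step is expected to stay within the scatter, with no clear direction: a 1.2-fold higher number from compound 3 to compound 4 (0.08 log units; within the scatter). The estimate for compound 4 is therefore 70000 nM, somewhere between 30000 nM and 160000 nM.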

Compound 4, half-maximal inhibitory concentration: > 100000 nM
Compound 4 was reported as a limit; the forecaster's own chance of this, stated with the estimate: 30%; at least 1.4-fold (0.15 log units) between middle value and limit.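

Compound 4 is reported only as a limit of the assay, > 100000 nM. Among the compounds shown here, putting 2-chloro-4-fluorophenyl in place of 4-chlorophenyl on the carbonyl carbon gives the first step that can be read at this position in this assay, an at least 1.7-fold higher number from compound 3 to compound 4 (0.23 log units; that floor lies within the scatter). Only a floor is known for this step, so its true size stays uncertain, but the result shows that a halogen-bearing ring here does not guarantee a number on the scale, and that the limit is not confined to compound 2 with its methylsulfonyl group: the limit of > 100000 nM in this assay, at which 2 of the 4 values shown sit.

Going by these compounds, the step linking compound 2 and compound 4 cannot be read, and the change from compound 3 to compound 4 alters the ring in two places at once, so the separate contributions of the chloro and the fluoro remain unknown. Also open, on these data alone, is how a ring bearing an amine or a carboxylic acid, or a longer alkyl chain in place of the ring, would read in this assay on this carbonyl carbon.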